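The source may hold more compounds than are shown below. What is called first, only, known or untested is meant among the compounds shown, and "the series" means these compounds.

Compound 1 `S=c1oc(-c2ccc3c(c2)OCCO3)nn1CN1CCN(c2ccc(Cl)cc2)CC1` in a functional assay on HepG2 cells (Homo sapiens) for antiproliferative activity, read by MTT assay, with a stated time of 48 h (on this read-out higher numbers stand for weaker inhibition and lower numbers for stronger inhibition), reports only a limit, > 50000 nM. Compound 2 `S=c1oc(-c2ccc3c(c2)OCCO3)nn1CN1CCN(C(c2ccccc2)c2ccccc2)CC1` gives 9120 nM. Compound 3 `Cc1ccc(N2CCN(Cn3nc(-c4ccc5c(c4)OCCO5)oc3=S)CC2)c(C)c1` gives 28400 nM.

Of the two numbers in this assay, compound 3 stands highest, with compound 2 below it by more than the usual scatter. Compound 4 `S=c1oc(-c2ccc3c(c2)OCCO3)nn1CN1CCN(c2ccccn2)CC1` differs from compound 3 by a single change: pyridin-2-yl in place of 2,4-dimethylphenyl on an amine nitrogen in a ring. For the measured compounds named here, the only measured step at the same place is an at least 1.7-fold lower number from compound 1 to compound 3 (0.24 log units; that floor lies within the scatter), and its size is uncertain because it rests on a limit, (the limit of > 50000 nM in this assay, at which 1 of the 3 values shown sits). A second exchange at the amine nitrogen in a ring therefore has no firm guide in this assay. For compound 4 the step expected is a 1.1-fold higher number from compound 3 to compound 4 (0.02 log units; within the scatter), none beyond the scatter. Compound 4 is estimated at 30000 nM, between 10000 nM and 90000 nM.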

Compound 4, half-maximal inhibitory concentration: 11400 nM
Compound 4: middle estimate off by 2.6-fold (0.42 log units), on the high side, and the stated range covers the measured number.
By their numbers in this assay, from the lowest: compounds 2 and 4 (each within the scatter of the next); then compound 3. At a limit, above all of these: compound 1.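

For the compounds shown here, at this amine nitrogen in this assay, pyridin-2-yl in place of 2,4-dimethylphenyl gives a 2.5-fold lower number from compound 3 to compound 4 (0.40 log units; beyond the scatter), the first step here with a firm size that lies beyond the scatter. Against 4-chlorophenyl, pyridin-2-yl gives an at least 4.3-fold lower number from compound 1 to compound 4 (0.64 log units; beyond the scatter); this size is only a floor, resting on a limit: the limit of > 50000 nM in this assay, at which 1 of the 4 values shown sits.

The change brings in a ring nitrogen and removes two methyl groups, and the compounds shown do not separate these two differences. On these data alone, how an unsubstituted phenyl or a pyridin-4-yl on the same nitrogen would read remains open.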